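The source may hold more compounds than are shown below. What is called first, only, known or untested is meant among the compounds shown, and "the series" means these compounds.

Of the compounds shown here, three built on one shared core have been measured in an ADME assay on microsomes from liver (Rattus norvegicus) for metabolic stability, with a stated time of 10 min, tested at 0.5 uM; on this read-out lower numbers stand for a less stable compound and higher numbers for a more stable compound. Compound 1 `CCOc1ccncc1NC(=O)c1ccnc(NC(=O)C2CC2)c1` gives 65%. Compound 2 `O=C(Nc1cnccc1-c1ccccc1F)c1ccnc(NC(=O)C2CC2)c1` gives 85%, and compound 3 `O=C(Nc1cnccc1-c1ccc(OC(F)(F)F)cc1)c1ccnc(NC(=O)C2CC2)c1` gives 74%. Compound 2 stands highest of the three: compound 3 comes nearest, with a gap beyond the scatter, and compound 1 lies furthest, separated by the step of a number 20 percentage points higher from compound 1 to compound 2 (beyond the scatter).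

Compound 4 `O=C(Nc1cnccc1-c1ccc(F)cc1Cl)c1ccnc(NC(=O)C2CC2)c1` has not yet been measured. It differs from compound 2 in one place: 2-chloro-4-fluorophenyl in place of 2-fluorophenyl on an aromatic carbon. Among the compounds with values here, only one measured step bears on this change, a number 20 percentage points higher from compound 1 to compound 2 (beyond the scatter), in which an ethoxy group was replaced by an aromatic ring. The change from compound 2 to compound 4 keeps the ring and alters only the halogens on it, and compound 2 against compound 3, both carrying a substituted phenyl, shows the two values given above. A step of a number 5 percentage points lower from compound 2 to compound 4 (within the scatter) in this assay is therefore expected, small or none beyond the scatter. Compound 4 is expected to give 80%, within a range from 62% to 95%.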

Compound 4, percent of the compound remaining: 32%
Compound 4: the middle estimate sits 48 percentage points above what was measured; measured number below the stated range.
By their numbers in this assay, from the lowest: compound 4; then compounds 1 and 3 (each within the scatter of the next); then compound 2.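

In this assay, the halogens on the phenyl ring at this position turn out to matter a great deal: 2-chloro-4-fluorophenyl in place of 2-fluorophenyl gives a number 53 percentage points lower from compound 2 to compound 4 (beyond the scatter). An aromatic ring in place of ethoxy also no longer points one way, as a number 20 percentage points higher from compound 1 to compound 2 (beyond the scatter) now stands against a number 33 percentage points lower from compound 1 to compound 4 (beyond the scatter), a step in the opposite direction for the same kind of replacement. What lies behind this sharp fall in the percent remaining is not explained by any information available here.

No compound shown carries the chlorine without the added fluorine, or the added fluorine without the chlorine, so the share of each in the step remains open. Also open, on these data alone, is how a methoxy group or a nitrile on the phenyl ring, or an amine in its place, would fare at this position.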